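Moving the Furan Attachment Point on a Nucleoside Core

The source may report more compounds than this note shows. Statements on the series, on what has been measured and on what is new or still open speak of the compounds shown alone.

Compound 3 `Nc1nc(N)c2c(-c3ccoc3)cn([C@@H]3O[C@H](CO)[C@@H](O)[C@H]3O)c2n1` carries a furan-3-yl group on the shared core. In a functional assay on HCT-116 cells (Homo sapiens), read by MTT assay, with a stated time of 72 h (on this read-out higher numbers stand for weaker inhibition and lower numbers for stronger inhibition), compound 3 gives only a limit, > 20000 nM. Its nearest measured neighbour, compound 1 `Nc1nc(N)c2c(-c3ccccc3)cn([C@@H]3O[C@H](CO)[C@@H](O)[C@H]3O)c2n1`, bears phenyl at the same place. In this assay compound 1 likewise reaches only the limit, > 20000 nM. The step that the two limits leave unreadable from compound 1 to compound 3 therefore cannot be read. Compound 2 `COc1nc(N)nc2c1c(-c1ccco1)cn2[C@@H]1O[C@H](CO)[C@@H](O)[C@H]1O`, which differs from the others in more than one place, stands at > 20000 nM in this assay, again a limit. Among the measured compounds shown here, all three measured values sit at the limit of > 20000 nM in this assay, at which 3 of the 3 values shown sit, so no step among them has a readable size.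

Compound 4 `Nc1nc(N)c2c(-c3ccco3)cn([C@@H]3O[C@H](CO)[C@@H](O)[C@H]3O)c2n1` is yet to be measured. It differs from compound 3 by furan-2-yl in place of furan-3-yl on an aromatic carbon. For the measured compounds named here, because every measured neighbour stands at the limit of > 20000 nM in this assay, at which 3 of the 3 values shown sit, no step bears on this change, and nothing beyond the scatter is expected in this assay. The step that the limit leaves unreadable from compound 3 to compound 4 is expected to be negligible. Compound 4 is expected to give 30000 nM in this assay, within 10000 nM to 100000 nM, most probably reported again only as a limit.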

Compound 4, half-maximal inhibitory concentration: > 20000 nM
Compound 4: a limit, no number; the forecaster's own chance of this, stated with the estimate: 85%; the middle value does not contradict the limit.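

Compound 4 also reaches only a limit in this assay, so its steps from compound 1, compound 2 and compound 3 cannot be read: the limit of > 20000 nM in this assay, at which 4 of the 4 values shown sit.

The compounds shown leave open how phenyl, furan-3-yl and furan-2-yl compare at this place on the shared core.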